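A few compounds are considered here, and "the series" means these few. Any claim that something is new, unique, unknown or untested is made for them only; others in the source may bear on it.

Measured so far in a toxicity assay on MT4 cells (Homo sapiens) for cytotoxicity, read by MTT assay; a higher number here means that more compound is tolerated, a lower number that less compound is tolerated:
- compound 1 `COc1cc(Oc2cc(N)nc(Nc3ccc(C#N)cc3)n2)ccc1-c1ccc(C#N)cc1`: 12900 nM
- compound 2 `Cc1cc(-c2ccccc2Cl)cc(C)c1Oc1cc(N)nc(Nc2ccc(C#N)cc2)n1`: 25100 nM
- compound 3 `Cc1cc(-c2ccc(Cl)cc2)cc(C)c1Oc1cc(N)nc(Nc2ccc(C#N)cc2)n1`: 21500 nM

All three compounds are tolerated at similar concentrations. Compound 3, at 21500 nM, lies within the usual scatter of both compound 2 and compound 1, so it cannot be ranked against either.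

The next compound is compound 4 `Cc1cc(-c2ccccc2C#N)cc(C)c1Oc1cc(N)nc(Nc2ccc(C#N)cc2)n1`, which has 2-cyanophenyl in place of the 4-chlorophenyl of compound 3 on an aromatic carbon: 2-cyanophenyl in place of 4-chlorophenyl on an aromatic carbon.

Within the data shown here, only one measured step bears on this site, a 1.2-fold lower number from compound 2 to compound 3 (0.07 log units; within the scatter). That change moved the chlorine within the chlorophenyl group and left this assay unchanged within the scatter. Among the measured compounds shown here, no measured step replaces a chlorophenyl with a cyanophenyl, so this evidence is indirect. No shift beyond the scatter is therefore expected, and no direction can be favoured.

The estimated step is a 1.1-fold lower number from compound 3 to compound 4 (0.03 log units; within the scatter). For compound 4, the expected value is 20000 nM, with an estimated range of 10000 nM to 40000 nM.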

Compound 4, half-maximal cytotoxic concentration: 25400 nM
Compound 4: the middle estimate sits 1.3-fold (0.10 log units) below what was measured, and the stated range covers the measured number.
By their numbers in this assay, from the lowest: compounds 1, 3, 2 and 4 (each within the scatter of the next).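

Among the earlier compounds, the only change at this position moved the chlorine around the chlorophenyl group; here the chlorine itself gives way to a cyano group. In this assay, replacing 4-chlorophenyl with 2-cyanophenyl gives a 1.2-fold higher number from compound 3 to compound 4 (0.07 log units; within the scatter), and the simpler swap of cyano for chloro gives a 1.0-fold higher number from compound 2 to compound 4 (0.01 log units; within the scatter), so neither change moves the number beyond the scatter. Nothing measured here offers an explanation for this.

As far as these compounds go, it remains open whether an amine or a carboxylic acid on this phenyl ring would also stay within the scatter in this assay. It is also unknown what would happen if a saturated chain, such as a longer alkyl chain, took the place of the whole phenyl ring on this aromatic carbon.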